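Chloro in place of methoxy on compound 2

The source may hold more compounds than are shown below. What is called first, only, known or untested is meant among the compounds shown, and "the series" means these compounds.

In a functional assay on RAW264.7 cells (Mus musculus) for inhibition, with stated times of 2 h and 24 h (a lower number here means a stronger inhibitor, a higher number a weaker inhibitor), compound 1 `COc1ccc(CSC2c3cc(OC)cc(OC)c3[C@@H](c3ccc(OC)cc3)[C@@H]2c2cc(OC)cc(OC)c2)cc1` gives 12500 nM. Compound 2 `COc1ccc(C(O)C2c3cc(OC)cc(OC)c3[C@@H](c3ccc(OC)cc3)[C@@H]2c2cc(OC)cc(OC)c2)cc1` gives > 200000 nM, a limit of the assay and not a number. Compound 3 `COc1ccc([C@@H]2c3c(OC)cc(OC)cc3C(C(O)c3ccc(Cl)cc3)[C@H]2c2cc(OC)cc(OC)c2)cc1` differs from compound 2 by chloro in place of methoxy on an aromatic carbon. For the measured compounds named here, the only measured step is an at least 16-fold higher number from compound 1 to compound 2 (1.20 log units; beyond the scatter). It is large but changes a different group, so it gives no size for this exchange. No step beyond the scatter is expected in this assay, and the expected step is a number no higher from compound 2 to compound 3 (the limit leaves the size open). Compound 3 is expected at 200000 nM, within an estimated range of 60000 nM to 400000 nM.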

Compound 3, half-maximal inhibitory concentration: > 200000 nM
Compound 3 was reported as a limit; the forecaster's own chance of this, stated with the estimate: 65%; the middle value lies on the limit itself.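

In this assay compound 3 gives > 200000 nM as a limit of the assay and not a number. (4-Chlorophenyl)(hydroxy)methyl in place of (4-methoxybenzyl)sulfanyl gives an at least 16-fold higher number from compound 1 to compound 3 (1.20 log units; beyond the scatter) so the loss seen with the hydroxy-bearing group holds with 4-chlorophenyl as well as with 4-methoxyphenyl. The size of the chloro for methoxy exchange cannot be read, because both compounds sit at the same limit: the limit of > 200000 nM in this assay, at which 2 of the 3 values shown sit.

Open, from the compounds shown here alone, is whether chloro changes the value when the sulfanyl link is kept. Also open, going by these compounds, is whether an amine in place of the hydroxy brings a value back under the limit.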